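The source may hold more compounds than are shown below. What is called first, only, known or untested is meant among the compounds shown, and "the series" means these compounds.

Measured compounds:
compound 1, `CCS(=O)(=O)Nc1ccc(NC(=O)c2ccc(Cl)cc2)cc1C`, 68700 nM;
compound 2, `CCS(=O)(=O)Nc1ccc(NC(=O)c2ccc(Cl)c([N+](=O)[O-])c2)cc1C`, 141000 nM;
compound 3, `COc1cc(NC(=O)c2ccc(Cl)cc2)ccc1NS(C)(=O)=O`, 70000 nM.

All three values come from an ADME assay on RAW264.7 cells (Mus musculus) for cytotoxicity, read by MTT assay, with a stated time of 48 h; on this read-out lower numbers stand for stronger inhibition and higher numbers for weaker inhibition. Compound 2 differs from compound 1 by nitro in place of hydrogen on an aromatic carbon, and that change gave a 2.1-fold higher number from compound 1 to compound 2 (0.31 log units; beyond the scatter). Compound 3 differs from compound 1 in its core; the difference between the two cores is not broken down here. Compound 4, `COc1cc(NC(=O)c2ccc(Cl)c([N+](=O)[O-])c2)ccc1NS(C)(=O)=O`, is not yet measured in this assay; it differs from compound 3 by nitro in place of hydrogen on an aromatic carbon, the same change as from compound 1 to compound 2, since both changes sit at the same kind of place. The expectation for compound 4 therefore rests on that single earlier step: a step of about a 2.1-fold higher number from compound 3 to compound 4 (0.32 log units; beyond the scatter) is expected, about the size of a 2.1-fold higher number from compound 1 to compound 2 (0.31 log units; beyond the scatter). On this basis compound 4 is estimated at 145000 nM, within 80000 nM to 260000 nM.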

Compound 4, half-maximal inhibitory concentration: > 250000 nM
Compound 4: no number, only a limit; the forecaster's own chance of this, stated with the estimate: 20%; middle value at least 1.7-fold (0.23 log units) from the limit.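

In this assay, nitro in place of hydrogen on an aromatic carbon moved the number in the same direction on the second core, with an at least 3.5-fold higher number from compound 3 to compound 4 (0.55 log units; beyond the scatter). The direction of the change therefore carried over between these two cores, but nothing shows that its size did: the same change on two cores in this assay, a 2.1-fold higher number (0.31 log units; beyond the scatter) from compound 1 to compound 2 and an at least 3.5-fold higher number (0.55 log units; beyond the scatter) from compound 3 to compound 4; the limit leaves it open whether they differ

Compound 4 gives a limit and not a number, so this second step has no upper end: the limit of > 250000 nM in this assay, at which 1 of the 4 values shown sits.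

The compounds shown leave open whether an amine or a nitrile on that same aromatic carbon would move the number in the same direction. They also leave open whether the nitro step would hold on a third core.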